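This account rests on a few compounds, and the source may have more. Where it says the series, first, only, none or still open, it means among the compounds named here.

Compound 1 `O=C(COc1cccc2ccccc12)N/N=C/c1ccc(Br)cc1` was examined in an ADME assay on MT4 cells (Homo sapiens) for cytotoxicity, read by MTT assay, with a stated time of 4 days (a lower number here means that less compound is tolerated, a higher number that more compound is tolerated), where compound 1 gives 106 ug/mL. Among the three compounds measured it stands at the top of the numbers, but neither gap is more than the usual scatter: compound 2 `O=C(COc1cccc2ccccc12)N/N=C/c1ccc([N+](=O)[O-])cc1` gives 87.9 ug/mL in this assay, and compound 3 `C/C(=N\NC(=O)COc1cccc2ccccc12)c1ccc(O)cc1O` gives 59.9 ug/mL. For the measured compounds named here, the one directly comparable step, a 1.2-fold lower number from compound 1 to compound 2 (0.08 log units; within the scatter), did not move the read-out beyond the scatter.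

Compound 4 `O=C(COc1cccc2ccccc12)N/N=C/c1cccc(Cl)c1` has not yet been measured in this assay. It differs from compound 1 in one place: 3-chlorophenyl in place of 4-bromophenyl on a carbon with a double bond to nitrogen. Going by the values given here, no measured step touches this exact exchange of one halogen-bearing phenyl for another; the only step available, from compound 1 to compound 2, was within the scatter, and compound 3, with a different attachment to the same core, also sits within the scatter of compound 1. On that basis compound 4 is expected to show no step beyond the scatter, a 1.1-fold lower number from compound 1 to compound 4 (0.03 log units; within the scatter). The estimate for compound 4 in this assay is 100 ug/mL, expected between 60 ug/mL and 150 ug/mL.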

Compound 4, half-maximal cytotoxic concentration: 89.9 ug/mL
For compound 4 the middle estimate is 1.1-fold (0.05 log units) above the measured one; low and high end bracket the measured number.
By their numbers in this assay, from the lowest: compounds 3, 2, 4 and 1 (each within the scatter of the next).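

The step of a 1.2-fold lower number from compound 1 to compound 4 (0.07 log units; within the scatter) in this assay shows that this place tolerates a second kind of exchange, one in which the halogen and its numbered ring position differ together. Like the earlier exchange of bromo for nitro, 3-chlorophenyl in place of 4-bromophenyl on a carbon with a double bond to nitrogen stays within the scatter, so the three aryl variants shown here cannot be told apart by this read-out. Nothing at hand offers an explanation for this result.

The compounds shown do not separate the identity of the halogen from its ring position, since compound 4 differs from compound 1 in both at once. Also open, on these data alone, is whether an amine or a carboxylic acid on this phenyl ring, or a longer chain in its place, would remain within the scatter of compound 1.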